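The source may hold more compounds than are shown below. What is called first, only, known or untested is meant among the compounds shown, and "the series" means these compounds.

Three compounds sharing a core were tested in an ADME assay on Raji cells (Homo sapiens) for cytotoxicity, read by luminescence, with a stated time of 72 h; a lower number here means that less compound is needed, a higher number that more compound is needed for the effect. Compound 1 `CCOC(=O)c1c(-c2cccc(Oc3ccccc3)c2)[nH]c2cc(OC)c(OC)cc2c1=O` returns only a limit of the assay and no number, > 21500 nM. Compound 2 `CCOC(=O)c1c(-c2cccc(Oc3ccccc3)c2)[nH]c2cc(Cl)c(OC)cc2c1=O` likewise sits at a limit, > 21500 nM. Compound 3 `CCOC(=O)c1c(-c2cccc(-c3ccccc3)c2)[nH]c2cc(Cl)c(Cl)cc2c1=O` also gives nothing more than a limit, > 21500 nM. Compound 1 differs from compound 2 by methoxy in place of chloro on an aromatic carbon, and the step that the two limits leave unreadable from compound 2 to compound 1 cannot be sized because the limit of > 21500 nM in this assay, at which 3 of the 3 values shown sit, holds all three values. The difference between the cores of compound 2 and compound 3 is not broken down here. Compound 4 `CCOC(=O)c1c(-c2cccc(-c3ccccc3)c2)[nH]c2cc(OC)c(Cl)cc2c1=O` has not yet been measured; it differs from compound 3 by methoxy in place of chloro on an aromatic carbon. This is the same kind of change as that from compound 2 to compound 1, though the surroundings differ: in compound 4 the entering methoxy sits ortho to a chloro group, whereas in compound 1 it sits ortho to a methoxy group. The step from compound 3 to compound 4 is expected to be a step that the limit leaves unreadable from compound 3 to compound 4. That expectation rests on compound 3, whose > 21500 nM is a limit, and on (the limit of > 21500 nM in this assay, at which 3 of the 3 values shown sit). Compound 4 is therefore estimated at 30000 nM, with a range from 10000 nM to 100000 nM.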

Compound 4, half-maximal effective concentration: > 21500 nM
Compound 4 gave a limit, no number (the forecaster's own chance of this, stated with the estimate: 85%); the middle value is on the limit's open side.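

In this assay compound 4 gives only a limit, > 21500 nM, so no step from compound 3 to compound 4 can be read, because both compounds sit at the same limit: the limit of > 21500 nM in this assay, at which 4 of the 4 values shown sit.

The compounds shown leave open whether methoxy in place of chloro changes this read-out at all, as none of the four gives a number.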